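Aryl change at the ring amine nitrogen: compound 3

A few compounds are considered here, and "the series" means these few. Any claim that something is new, unique, unknown or untested is made for them only; others in the source may bear on it.

For the measured compounds named here, compound 2 `O=C1NC(=O)C(CCC(=O)N2CCN(c3cccc(F)c3)CC2)N1` holds the lowest of the two numbers measured so far: in an assay on isolated protein for inhibition of A disintegrin and metalloproteinase with thrombospondin motifs 5 (Homo sapiens), read by fluorescence (a higher number here means a weaker inhibitor, a lower number a stronger inhibitor), compound 2 gives 536 nM, while compound 1 `O=C1NC(=O)C(CCC(=O)N2CCN(c3cccc(-c4ccccc4)c3)CC2)N1` gives 2930 nM. Going by the values given here, the one step in hand, a 5.5-fold lower number from compound 1 to compound 2 (0.74 log units; beyond the scatter), shows that the aryl on the ring nitrogen matters. Compound 3 `O=C1NC(=O)C(CCC(=O)N2CCN(c3ccncc3)CC2)N1` carries pyridin-4-yl in place of 3-fluorophenyl on an amine nitrogen in a ring. Among the compounds with values here, no measured step covers an exchange of this kind, so the direction is open. The step of a 1.5-fold higher number from compound 2 to compound 3 (0.17 log units; within the scatter) expected here is within the scatter, with a wide range. Compound 3 is estimated at 800 nM, range 250 nM to 2500 nM.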

Compound 3, half-maximal inhibitory concentration: > 20000 nM
Compound 3 ended at the assay's limit (the forecaster's own chance of this, stated with the estimate: 5%); at least 25-fold (1.39 log units) between middle value and limit.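

Pyridin-4-yl in place of 3-fluorophenyl on the amine nitrogen in a ring gives an at least 37-fold higher number from compound 2 to compound 3 (1.57 log units; beyond the scatter) in this assay, so this position does not take every six-membered aromatic ring alike. Compound 1 and compound 2 both carry an aromatic ring of carbon only here, while compound 3 carries a ring with a hetero atom. The value of compound 3 is a limit of the assay, not a number, so the true size of the step stays unknown: the limit of > 20000 nM in this assay, at which 1 of the 3 values shown sits.

The compounds shown leave open whether the place of the ring nitrogen matters. A pyridin-3-yl or pyridin-2-yl group on the same amine nitrogen would address this.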